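The source may report more compounds than this note shows. Statements on the series, on what has been measured and on what is new or still open speak of the compounds shown alone.

Among the compounds with values here, compound 2 (`c1cc([C@H]2CC[C@]3(CC2)OOC2(O3)C3CC4CC(C3)CC2C4)ccc1OCCC1CCNCC1`) holds the highest of the two numbers so far in an ADME assay on the whole organism (strain FVB) for pharmacokinetics, with Mus musculus as the target, read by LC-MS, at a dose of 30 mg/kg by the oral route; on this read-out higher numbers stand for higher exposure at the dose given and lower numbers for lower exposure: compound 2 gives 16000 ng.h/mL there, and compound 1 (`NCCOc1ccc([C@H]2CC[C@]3(CC2)OOC2(O3)C3CC4CC(C3)CC2C4)cc1`) gives 1370 ng.h/mL there. Compound 3 (`N[C@H]1CC[C@@H](Oc2ccc([C@H]3CC[C@]4(CC3)OOC3(O4)C4CC5CC(C4)CC3C5)cc2)CC1`) has 4-aminocyclohexyl in place of 2-(piperidin-4-yl)ethyl on an oxygen on an aromatic ring. Within the data shown here, only one measured step bears on this change: a 12-fold higher number from compound 1 to compound 2 (1.07 log units; beyond the scatter) with piperidin-4-yl in place of amino, large and beyond the scatter. The entering 4-aminocyclohexyl carries an amino group again, but also a six-membered non-aromatic ring, so only part of that step is expected to be undone. A moderate fall towards the lower number is therefore expected, an estimated 3.2-fold lower number from compound 2 to compound 3 (0.51 log units; beyond the scatter) in this assay for this change. For compound 3 the expected value is 5000 ng.h/mL within an estimated range from 1500 ng.h/mL to 16000 ng.h/mL in this measurement.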

Compound 3, area under the concentration-time curve: 13400 ng.h/mL
For compound 3 the middle estimate is 2.7-fold (0.43 log units) below the measured one; the range from low to high includes it.
By their numbers in this assay, from the lowest: compound 1; then compounds 3 and 2 (each within the scatter of the next).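

In this assay, the step shows a 1.2-fold lower number from compound 2 to compound 3 (0.08 log units; within the scatter), so the two compounds cannot be told apart, even though 4-aminocyclohexyl replaces 2-(piperidin-4-yl)ethyl on the oxygen on the aromatic ring. Set against the 2-aminoethyl group, the same group gives a 9.8-fold higher number from compound 1 to compound 3 (0.99 log units; beyond the scatter), so a six-membered non-aromatic ring need not hold a nitrogen, nor sit on a chain, for the number to stand well clear of compound 1. An amino group is therefore present at both the low and the high end of these numbers, and on its own it does not set the reading.

A plain cyclohexyl or a 4-hydroxycyclohexyl on that oxygen would test whether the amino group matters here at all. Why the ring-bearing compounds give the larger numbers remains open, as nothing here speaks to a cause.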